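Swapping a Carbamate Tail for an Amide Tail

A few compounds are considered here, and "the series" means these few. Any claim that something is new, unique, unknown or untested is made for them only; others in the source may bear on it.

Compound 1 `CC(C)COC(=O)NS(=O)(=O)c1sc(CC(C)C)cc1-c1cccc(Cn2ccnc2)c1` gives 130 nM in an assay on HEK293 cells for displacement of a labelled ligand from Type-2 angiotensin II receptor (Homo sapiens), read by scintillation counting, with a stated time of 240 min; a higher number here means a weaker inhibitor, a lower number a stronger inhibitor.
Compound 2 `CC(C)Cc1cc(-c2cccc(Cn3ccnc3)c2)c(S(=O)(=O)NC(=O)OC(C)(C)C)s1` gives 270 nM in this assay.
Compound 3 `CC(C)Cc1cc(-c2cccc(Cn3ccnc3)c2)c(S(=O)(=O)NC(=O)OCC2CC2)s1` gives 140 nM in this assay.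

All three share one core and differ only in the group on the oxygen next to the carbonyl. Compound 3 holds the second highest of the three numbers, but both of its neighbours sit within the scatter: a 1.1-fold higher number from compound 1 to compound 3 (0.03 log units; within the scatter) and a 1.9-fold lower number from compound 2 to compound 3 (0.29 log units; within the scatter). For the measured compounds named here, the only step beyond the scatter is a 2.1-fold higher number from compound 1 to compound 2 (0.32 log units; beyond the scatter), and even that is modest.

Compound 4 `CCCC(=O)NS(=O)(=O)c1sc(CC(C)C)cc1-c1cccc(Cn2ccnc2)c1` carries a different kind of change: propyl in place of cyclopropylmethoxy on a carbonyl carbon. Every measured step reshaped the group on the oxygen; none removed the oxygen itself, so they bear on this step only loosely. They show that the tail tolerates reshaping with little movement, which makes a small to modest step the expected outcome, with the direction uncertain; the estimate is a 2.1-fold higher number from compound 3 to compound 4 (0.33 log units; beyond the scatter). Compound 4 is therefore expected to give about 300 nM, within a range of 100 nM to 1000 nM.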

Compound 4, inhibition constant: 300 nM
For compound 4 middle estimate and measured number coincide at the digits printed, within the range that was stated.
By their numbers in this assay, from the lowest: compounds 1, 3, 2 and 4 (each within the scatter of the next, the first and the last beyond it).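

Until now only the group on the oxygen had varied; compound 4 shows that the whole alkoxy part can give way to propyl on the carbonyl carbon without a large loss in this assay. The size of the step depends on the partner: a 2.1-fold higher number from compound 3 to compound 4 (0.33 log units; beyond the scatter) and a 2.3-fold higher number from compound 1 to compound 4 (0.36 log units; beyond the scatter) are both modest, while a 1.1-fold higher number from compound 2 to compound 4 (0.05 log units; within the scatter) leaves propyl and tert-butoxy level. Nothing available explains these steps.

Propyl differs from cyclopropylmethoxy both in lacking the oxygen and in lacking the ring, and the compounds shown do not separate these two differences; cyclopropylmethyl set directly on the carbonyl carbon would change only the first. Also open, as far as these compounds go, is how a longer chain such as pentyl, or an amine on the carbonyl carbon, would read at this position.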